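This account rests on a few compounds, and the source may have more. Where it says the series, first, only, none or still open, it means among the compounds named here.

Measured compounds:
- compound 1 `Cc1cn2c(-c3cn[nH]c3)cnc2c(Nc2cc(Cn3cccc3)ns2)n1` — "not determined" (no result reported) in an ADME assay on the whole organism for pharmacokinetics, with Rattus norvegicus as the target, with a stated time of 6 h, at a dose of 10 mg/kg by the oral route; on this read-out lower numbers stand for lower exposure and higher numbers for higher exposure at the dose given
- compound 2 `Cc1cccc(Cc2cc(Nc3nc(C)cn4c(-c5cn[nH]c5)cnc34)sn2)n1` — 3100 ng.h/mL

Going by the values given here, compound 2 holds the only number in this assay; compound 1 carries no result there. Compound 3 `Cc1cn2c(-c3cn[nH]c3)cnc2c(Nc2cc(Cc3ccc(F)cn3)ns2)n1` differs from compound 2 by 5-fluoropyridin-2-yl in place of 6-methylpyridin-2-yl on a saturated chain carbon bound to an aromatic carbon. Among the compounds with values here, no step between two measured compounds is known here, so the size of this change in exposure cannot be read from the data. The expectation is a shift for compound 3 that stays within the usual scatter, of a 1.2-fold lower number from compound 2 to compound 3 (0.09 log units; within the scatter). For compound 3 the estimate in this assay is 2500 ng.h/mL, with a range from 900 ng.h/mL to 7000 ng.h/mL.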

Compound 3, area under the concentration-time curve: 2240 ng.h/mL
Estimate against measurement, compound 3: 1.1-fold (0.05 log units) above; the range from low to high includes it.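

Going by these compounds alone, the exchange on a saturated chain carbon bound to an aromatic carbon gives the first readable step in this assay (a 1.4-fold lower number from compound 2 to compound 3 (0.14 log units; within the scatter)). 5-Fluoropyridin-2-yl and 6-methylpyridin-2-yl are therefore not separated on this read-out, so the position accepts this exchange without a resolved shift in exposure. No supporting measurement bears on this result.

From the compounds shown here alone, both groups are substituted pyridines, so the effect of a wider change at this position stays open. An unsubstituted phenyl, an amine or a carboxylic acid in place of the pyridine could still give a step beyond the scatter.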